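Side-chain notes: from compound 1 to compound 3

The source may hold more compounds than are shown below. What is called first, only, known or untested is meant among the compounds shown, and "the series" means these compounds.

In a functional assay on SH-SY5Y cells (Homo sapiens) for cytotoxicity, read by MTT assay, with a stated time of 72 h (on this read-out lower numbers stand for stronger inhibition and higher numbers for weaker inhibition), compound 1 `O=C1c2c[n+]([O-])c3ccccc3c2C(=O)c2c1c1ccccc1n2Cc1cn(C[C@H](O)CO)nn1` gives > 1000 nM, which is a limit of the assay and not a number. In this assay compound 2 `O=C1c2c[n+]([O-])c3ccccc3c2C(=O)c2c1c1ccccc1n2CCN1CCCC1` gives 520 nM. Compound 3 `CC1(C)OC[C@H](Cn2cc(Cn3c4c(c5ccccc53)C(=O)c3c[n+]([O-])c5ccccc5c3C4=O)nn2)O1` carries 2,2-dimethyl-1,3-dioxolan-4-yl in place of 1,2-dihydroxyethyl on a saturated chain carbon bound to an aromatic nitrogen. Going by the values given here, the only measured step, an at least 1.9-fold lower number from compound 1 to compound 2 (0.28 log units; that floor lies within the scatter), is a different replacement and bears on this change only loosely. Compound 1 stands at the limit of > 1000 nM in this assay, at which 1 of the 2 values shown sits, so the series gives no direction for the change, and no step beyond the scatter is expected in this assay. The expected step is a step that the limit leaves unreadable from compound 1 to compound 3. The estimate for compound 3 is 1500 nM, with an expected range from 500 nM to 5000 nM.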

Compound 3, half-maximal inhibitory concentration: 820 nM
Compound 3: the middle estimate sits 1.8-fold (0.26 log units) above what was measured, within the range that was stated.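

In this assay compound 3 gives 820 nM: with 2,2-dimethyl-1,3-dioxolan-4-yl in place of 1,2-dihydroxyethyl, this side chain now has a measured number. Compound 1 gives > 1000 nM, which is a limit of the assay and not a number. The change therefore reads only as an at least 1.2-fold lower number from compound 1 to compound 3 (0.08 log units; that floor lies within the scatter), so its true size and whether it exceeds the scatter remain unreadable: the limit of > 1000 nM in this assay, at which 1 of the 3 values shown sits.

The compounds shown do not separate the loss of the hydrogen-bond donors from the gain of the five-membered ring, as the two arrive together in this change. Also open, going by these compounds, is how a carboxylic acid or a morpholine, on a saturated chain carbon bound to an aromatic nitrogen, would read in this assay.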